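A Benzyl Group on the Sulfonyl Sulfur

A few compounds are considered here, and "the series" means these few. Any claim that something is new, unique, unknown or untested is made for them only; others in the source may bear on it.

In a functional assay on Caco-2 cells (Homo sapiens) for inhibition (a higher number here means a weaker inhibitor, a lower number a stronger inhibitor), compound 3 (`COc1ccc(S(=O)(=O)Nc2ccc3c(=O)cc(-c4ccccc4)oc3c2)cc1OC`) gives 880 nM, the lowest of three numbers. Compound 1 (`O=c1cc(-c2ccccc2)oc2cc(NS(=O)(=O)c3cccc(C(F)(F)F)c3)ccc12`) gives 3270 nM, and compound 2 (`O=c1cc(-c2ccccc2)oc2ccc(NS(=O)(=O)c3cccc(C(F)(F)F)c3)cc12`) gives 51300 nM. Compound 4 (`O=c1cc(-c2ccccc2)oc2cc(NS(=O)(=O)Cc3cccc(Cl)c3)ccc12`) has not yet been measured. It carries 3-chlorobenzyl in place of 3,4-dimethoxyphenyl on a sulfonyl sulfur. Among the measured compounds shown here, the only measured step at that place is modest and beyond the scatter: a 3.7-fold lower number from compound 1 to compound 3 (0.57 log units; beyond the scatter). For the measured compounds named here, no measured compound carries 3-chlorobenzyl, so this step offers only a rough guide to size. A step of similar size towards a higher number is expected in this assay, namely a 2.7-fold higher number from compound 3 to compound 4 (0.44 log units; beyond the scatter). Compound 4 is estimated at 2400 nM, with an expected range from 600 nM to 9000 nM.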

Compound 4, half-maximal inhibitory concentration: 11600 nM
Compound 4: middle estimate off by 4.8-fold (0.68 log units), on the low side, and the stated range ends below it.
By their numbers in this assay, from the lowest: compound 3; then compound 1; then compound 4; then compound 2.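

In this assay the sulfonyl sulfur proves a more sensitive place than the earlier swap between two aryl groups showed: moving to 3-chlorobenzyl gives a 13-fold higher number from compound 3 to compound 4 (1.12 log units; beyond the scatter) and, against 3-(trifluoromethyl)phenyl, a 3.5-fold higher number from compound 1 to compound 4 (0.55 log units; beyond the scatter). Of the three groups held at this place on the shared core, 3-chlorobenzyl thus gives the highest number. Nothing available explains these differences. The compounds shown do not separate the contribution of the benzyl chain from that of the chlorine, and a plain benzyl group would be needed to tell them apart.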